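The source may report more compounds than this note shows. Statements on the series, on what has been measured and on what is new or still open speak of the compounds shown alone.

Working notes on the series. In a functional assay on MCF7 cells (Homo sapiens) for antiproliferative activity, read by MTT assay, with a stated time of 24 h (a higher number here means a weaker inhibitor, a lower number a stronger inhibitor), compound 1 `COC(=O)c1scc(-c2ccc(NC(=O)c3cccc(C(F)(F)F)c3)cc2)c1OC` gives 26200 nM, and compound 2 `COC(=O)c1scc(-c2ccc(NC(=O)c3ccc(OC)nc3)cc2)c1OC` gives 5250 nM, the lower of the two numbers and so the stronger inhibitor of this pair. The next analogue is compound 3 `COC(=O)c1scc(-c2ccc(NC(=O)c3ccc(C(F)(F)F)cc3)cc2)c1OC`, which differs from compound 2 as follows: 4-(trifluoromethyl)phenyl in place of 6-methoxypyridin-3-yl on a carbonyl carbon. This places 4-(trifluoromethyl)phenyl in place of 6-methoxypyridin-3-yl on a carbonyl carbon.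

Among the measured compounds shown here, only one measured step bears on this change: a 5.0-fold lower number from compound 1 to compound 2 (0.70 log units; beyond the scatter), with 6-methoxypyridin-3-yl in place of 3-(trifluoromethyl)phenyl at that same place. For the measured compounds named here, the new change runs roughly the reverse way, although the group entering is 4-(trifluoromethyl)phenyl rather than 3-(trifluoromethyl)phenyl, and no measurement yet separates those two groups. A step of similar size is therefore expected in this assay, towards a higher number and weaker inhibition, with wide uncertainty since it rests on one pair. The expected step is a 3.8-fold higher number from compound 2 to compound 3 (0.58 log units; beyond the scatter). Compound 3 is estimated at 20000 nM, with an expected range of 7000 nM to 60000 nM.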

Compound 3, half-maximal inhibitory concentration: 24600 nM
Compound 3: the middle estimate sits 1.2-fold (0.09 log units) below what was measured; low and high end bracket the measured number.
By their numbers in this assay, from the lowest: compound 2; then compounds 3 and 1 (each within the scatter of the next).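

Working from this assay, the step on swapping 3-(trifluoromethyl)phenyl for 4-(trifluoromethyl)phenyl on the carbonyl carbon (a 1.1-fold lower number from compound 1 to compound 3 (0.03 log units; within the scatter)) lies within the scatter, so this assay does not tell these two groups apart. The earlier compounds shown here left that question untested, and the comparison with compound 2 now rests on two trifluoromethyl-bearing analogues rather than one: 4-(trifluoromethyl)phenyl in place of 6-methoxypyridin-3-yl gives a step beyond the scatter (a 4.7-fold higher number from compound 2 to compound 3 (0.67 log units; beyond the scatter)), of similar size to the one first seen with the other group. Among these three compounds, compound 2 is therefore the strongest inhibitor, although no measurement here accounts for its separation from the other two.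

The change from 6-methoxypyridin-3-yl to either trifluoromethyl-bearing group alters the ring and its substituent at once, so the compounds shown cannot assign the difference to the ring nitrogen, the methoxy group or the loss of the trifluoromethyl group. An unsubstituted phenyl, or a pyridine ring carrying an amine or a carboxylic acid in place of the methoxy group, would be needed to begin separating these contributions.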